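This account rests on a few compounds, and the source may have more. Where it says the series, first, only, none or still open, it means among the compounds named here.

Of the compounds shown here, two from this series have been measured in an assay on FRT cells for positive allosteric modulation of Cystic fibrosis transmembrane conductance regulator variant N1303K (Homo sapiens), in the presence of a further agent that is not named here; on this read-out lower numbers stand for an effect already at smaller amounts and higher numbers for an effect only at larger amounts of compound. Compound 1 `COc1ccc2[nH]c3c(c2c1)CCNC31CCN(Cc2ccc(Br)cc2F)CC1` gives 1600 nM in this assay. Compound 2 `COc1ccc2[nH]c3c(c2c1)CCNC31CCN(Cc2cc(F)cc(F)c2)CC1` gives 11100 nM in this assay. Between them lies one change, a 3,5-difluorophenyl in place of a 4-bromo-2-fluorophenyl on a saturated chain carbon bound to an amine nitrogen in a ring, and that step reads a 6.9-fold higher number from compound 1 to compound 2 (0.84 log units; beyond the scatter). Within the data shown here, compound 2 thus stands with the highest number of the two measured compounds, with compound 1 as its only neighbour.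

Compound 3 `COc1ccc2[nH]c3c(c2c1)CCNC31CCN(Cc2ccc(F)c(F)c2)CC1` differs from compound 2 in one place: 3,4-difluorophenyl in place of 3,5-difluorophenyl on a saturated chain carbon bound to an amine nitrogen in a ring. The two have the same atoms, joined differently. Among the measured compounds shown here, the only measured step, the one from compound 1 to compound 2, swaps a different pair of groups and so says little about how moving one fluorine on the same ring will play out. For the measured compounds named here, with no step of this kind on record, the expectation for compound 3 is a change no larger than modest in this assay, in either direction, expressed as a 1.9-fold lower number from compound 2 to compound 3 (0.27 log units; within the scatter). Compound 3 is therefore estimated at 6000 nM in this assay, with a range from 1800 nM to 20000 nM.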

Compound 3, half-maximal effective concentration: 11000 nM
For compound 3 the middle estimate is 1.8-fold (0.26 log units) below the measured one; the measured number falls inside the stated range.
By their numbers in this assay, from the lowest: compound 1; then compounds 3 and 2 (each within the scatter of the next).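

In this assay, 3,4-difluorophenyl in place of 3,5-difluorophenyl gives a 1.0-fold lower number from compound 2 to compound 3 (0.00 log units; within the scatter), so on this saturated chain carbon bound to an amine nitrogen in a ring, these two arrangements of the same atoms cannot be told apart. The 4-bromo-2-fluorophenyl of compound 1 now stands apart from both difluorophenyl groups: the new comparison reads a 6.9-fold higher number from compound 1 to compound 3 (0.84 log units; beyond the scatter), matching the earlier 6.9-fold higher number from compound 1 to compound 2 (0.84 log units; beyond the scatter), so among these three compounds the gap to compound 1 does not hang on one particular difluorophenyl arrangement. Nothing available here explains why the two fluorine arrangements read alike or why compound 1 differs from both.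

On these data alone, the 4-bromo-2-fluorophenyl group differs from both difluorophenyl groups in more than one respect, so it remains open whether the bromine, the placement of the fluorine or the two together account for the gap to compound 1. Also open, as far as these compounds go, is how a chlorophenyl group, a pyridine ring or a longer chain carrying the phenyl ring would read at this place in this assay.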